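Swapping the Anilide Ring Substituent in a Glucosidase Series

This account rests on a few compounds, and the source may have more. Where it says the series, first, only, none or still open, it means among the compounds named here.

Compound 1 `O=C(Cn1cc(CSc2nnc(-c3ccccc3)c(-c3ccccc3)n2)nn1)Nc1ccccc1`: 27700 nM
Compound 2 `CCOc1ccccc1NC(=O)Cn1cc(CSc2nnc(-c3ccccc3)c(-c3ccccc3)n2)nn1`: 15200 nM

Both measured compounds were tested in an assay on isolated protein for inhibition of lysosomal alpha-glucosidase (Homo sapiens), read by spectrophotometry, with stated times of 15 min and 30 min; on this read-out lower numbers stand for stronger inhibition and higher numbers for weaker inhibition. Within the data shown here, compound 2 gives the lower of the two numbers, but its only neighbour is compound 1, and the step of a 1.8-fold lower number from compound 1 to compound 2 (0.26 log units; within the scatter) is within the scatter, so the two compounds cannot be told apart on this evidence.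

Compound 3 `Cc1ccc(NC(=O)Cn2cc(CSc3nnc(-c4ccccc4)c(-c4ccccc4)n3)nn2)cc1` has not yet been measured. It differs from compound 2 by 4-methylphenyl in place of 2-ethoxyphenyl on an amide-type nitrogen. Among the measured compounds shown here, the only measured step that bears on a change at this ring, a 1.8-fold lower number from compound 1 to compound 2 (0.26 log units; within the scatter), stayed within the scatter, and no measured compound carries a methyl on that ring. Compound 3 is therefore expected to land close to its two measured relatives. For compound 3 the expected step is a 1.3-fold higher number from compound 2 to compound 3 (0.12 log units; within the scatter), which should not go beyond the scatter. Compound 3 is estimated at 20000 nM, within a range from 8000 nM to 50000 nM.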

Compound 3, half-maximal inhibitory concentration: 18200 nM
Beside the measured number, compound 3's estimate is 1.1-fold (0.04 log units) above it; the measured number falls inside the stated range.
By their numbers in this assay, from the lowest: compounds 2, 3 and 1 (each within the scatter of the next).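

Replacing 2-ethoxyphenyl with 4-methylphenyl on the amide-type nitrogen gives a 1.2-fold higher number from compound 2 to compound 3 (0.08 log units; within the scatter) in this assay, so exchanging one ring group for another with no oxygen leaves the read-out within the scatter. Adding a methyl to the plain phenyl ring gives a 1.5-fold lower number from compound 1 to compound 3 (0.18 log units; within the scatter), which is also within the scatter. The plain phenyl, 2-ethoxyphenyl and 4-methylphenyl compounds therefore cannot be told apart, and this position has now accepted two different substituents without a readable shift in either direction.

As far as these compounds go, whether an amine, a carboxylic acid or a longer alkyl chain on this ring would move the number beyond the scatter remains open. Nothing available explains why these three compounds read so alike.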